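The compounds below may be only part of what the source reports. "The series", "measured", "known", "first", "only" and "open" are said of these compounds alone.

Measured compounds in this assay:
compound 1 `Cc1nnc(SCC(=O)c2ccc(Cl)cc2)n1N1C(=O)c2ccccc2C1=O`: > 200000 nM
compound 2 `Cc1ccc(C(=O)CSc2nnc(C)n2N2C(=O)c3ccccc3C2=O)cc1`: > 200000 nM
compound 3 `Cc1nnc(SCc2ccccc2Cl)n1N1C(=O)c2ccccc2C1=O`: > 200000 nM

In a functional assay on MKN-45 cells (Homo sapiens) for cytotoxicity, read by MTT assay, with a stated time of 48 h (on this read-out higher numbers stand for weaker inhibition and lower numbers for stronger inhibition), compound 1 gives > 200000 nM, which is a limit of the assay. Compound 2 gives > 200000 nM, again a limit. Compound 3 gives > 200000 nM, also a limit. All three values sit at the limit of > 200000 nM in this assay, at which 3 of the 3 values shown sit, so the steps a step that the two limits leave unreadable from compound 1 to compound 2, a step that the two limits leave unreadable from compound 1 to compound 3 and a step that the two limits leave unreadable from compound 2 to compound 3 have no readable size. Compound 2 therefore stands only at a limit, with no number.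

Compound 4 `COc1cc(-c2nnc(SCC(=O)c3ccc(C)cc3)n2N2C(=O)c3ccccc3C2=O)cc(OC)c1OC` differs from compound 2 by 3,4,5-trimethoxyphenyl in place of methyl on an aromatic carbon. Going by the values given here, no measured step touches this position and none has a readable size, so no direction can be drawn from them. Compound 4 is expected near 120000 nM, within 20000 nM to 400000 nM. Among the compounds with values here, the expected step of an at least 1.6-fold lower number from compound 2 to compound 4 (0.22 log units; that floor lies within the scatter) rests on no measured step and is a guess.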

Compound 4, half-maximal inhibitory concentration: 9620 nM
Beside the measured number, compound 4's estimate is 12-fold (1.10 log units) above it; measured number outside the range, below it.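

In this assay, going by these compounds alone, 3,4,5-trimethoxyphenyl in place of methyl on the carbon between two ring nitrogen atoms gives an at least 20-fold lower number from compound 2 to compound 4 (1.31 log units; beyond the scatter), the only readable step. This position therefore responds to substitution, while all earlier steps cannot be read. Compound 4 alone has a number rather than a limit, and the other compounds stay at: the limit of > 200000 nM in this assay, at which 3 of the 4 values shown sit.

As far as these compounds go, it remains open whether a plain phenyl or a single methoxy-bearing phenyl would give the same step. An amine or a longer alkyl chain at this position is also untested in the compounds shown.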